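Methoxy in Place of Hydrogen on Compound 1

The source may hold more compounds than are shown below. What is called first, only, known or untested is meant among the compounds shown, and "the series" means these compounds.

Compound 1 `CC(=O)c1cc(-c2ccccc2)cc2cc(-c3ccccc3)[nH]c12` gives > 100000 nM
Compound 2 `CC(=O)c1cc(-c2ccc(F)cc2)cc2cc(-c3ccccc3)[nH]c12` gives 38000 nM

In a functional assay on HeLa cells (Homo sapiens) for cytotoxicity, read by MTT assay, with a stated time of 2 days (on this read-out higher numbers stand for lower toxicity in this test and lower numbers for higher toxicity in this test), compound 1 stands only at a limit, > 100000 nM, which is not a number but the edge of what the test reports. Compound 3 `COc1ccc(-c2cc3cc(-c4ccccc4)cc(C(C)=O)c3[nH]2)cc1` differs from compound 1 by methoxy in place of hydrogen on an aromatic carbon. Among the measured compounds shown here, the only measured step that bears on this change is an at least 2.6-fold lower number from compound 1 to compound 2 (0.42 log units; beyond the scatter), where a different group enters. For the measured compounds named here, since methoxy is not fluoro and that step is the sole guide, a modest lowering, if any, is expected: an at least 1.6-fold lower number from compound 1 to compound 3 (0.22 log units; that floor lies within the scatter). Compound 3 is therefore estimated at 60000 nM, between 20000 nM and 150000 nM.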

Compound 3, concentration lethal to 50% of the cells: 18900 nM
Estimate against measurement, compound 3: 3.2-fold (0.50 log units) above, and the stated range ends above it.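

Among the compounds shown here, the new result shows that a group on this phenyl ring, a different ring from the one carrying fluoro in compound 2, also makes the compound more toxic in this assay: phenyl to 4-methoxyphenyl gives an at least 5.2-fold lower number from compound 1 to compound 3 (0.72 log units; beyond the scatter). Compounds 2 and 3 differ in two places, so these two changes cannot be ranked against each other. The full size of this step stays unknown because compound 1 stands at a limit: the limit of > 100000 nM in this assay, at which 1 of the 3 values shown sits.

As far as these compounds go, whether an amine or a carboxylic acid in the same place would also lower the number remains open. So does the effect of a longer chain, such as ethoxy, in place of methoxy.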